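Trifluoromethyl for Bromo: One Step Measured, One Expected

A few compounds are considered here, and "the series" means these few. Any claim that something is new, unique, unknown or untested is made for them only; others in the source may bear on it.

Compound 1, `Cc1ccccc1NC(=S)N1CCc2c(sc(NC(=O)c3ccccc3Br)c2C(N)=O)C1`: in a functional assay on MKN-74 cells (Homo sapiens) for antiproliferative activity, with a stated time of 24 h (a higher number here means a weaker inhibitor, a lower number a stronger inhibitor), compound 1 gives > 50000 nM, which is a limit of the assay and not a number.
Compound 2, `Cc1ccccc1NC(=S)N1CCc2c(sc(NC(=O)c3ccccc3C(F)(F)F)c2C(N)=O)C1`: in this assay compound 2 gives 47400 nM.
Compound 3, `Cc1ccccc1C(=O)Nc1sc2c(c1C(N)=O)CCN(C(=S)Nc1ccccc1Br)C2`: in this assay compound 3 gives > 50000 nM, again only a limit.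

Compound 1 and compound 3 are made of the same atoms joined differently; how their two cores differ is not broken down here. From compound 1 to compound 2 the change is trifluoromethyl in place of bromo on an aromatic carbon. The measured step is an at least 1.0-fold lower number from compound 1 to compound 2 (0.02 log units; that floor lies within the scatter). Because compound 1 sits at the limit of > 50000 nM in this assay, at which 2 of the 3 values shown sit, that step is only a floor and says little more than that both values lie near the edge of what the assay reports.

Compound 4, `Cc1ccccc1C(=O)Nc1sc2c(c1C(N)=O)CCN(C(=S)Nc1ccccc1C(F)(F)F)C2`, differs from compound 3 by trifluoromethyl in place of bromo on an aromatic carbon. The place is described in the same words for both pairs, so this is the same change made on the other core; cut one bond further out it reads here (2-bromophenyl)amino to (2-(trifluoromethyl)phenyl)amino.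

For compound 4 the expected step is a number no higher from compound 3 to compound 4 (the limit leaves the size open), put beside the measured at least 1.0-fold lower number from compound 1 to compound 2 (0.02 log units; that floor lies within the scatter), and it rests on compound 3 giving > 50000 nM as a limit and on that earlier step lying within the scatter. Compound 4 is therefore estimated at 50000 nM in this assay, most likely reported again as a limit, with a range from 30000 nM to 100000 nM.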

Compound 4, half-maximal inhibitory concentration: 17400 nM
Compound 4: the middle estimate sits 2.9-fold (0.46 log units) above what was measured; measured number outside the range, below it.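

In this assay, putting trifluoromethyl in place of bromo on the core of compound 3 gives an at least 2.8-fold lower number from compound 3 to compound 4 (0.45 log units; beyond the scatter). This is a real change on that core, since the step lies beyond the usual scatter, but setting it against the same change on the core of compound 1 does not tell whether the two cores respond alike, as the comparison rests on floors and not on exact sizes: the same change on two cores in this assay, an at least 1.0-fold lower number (0.02 log units; that floor lies within the scatter) from compound 1 to compound 2 and an at least 2.8-fold lower number (0.45 log units; beyond the scatter) from compound 3 to compound 4; the limit leaves it open whether they differ

The pair of compound 3 and compound 4 therefore shows that this swap can lower the number on one core, but it does not show that the size of the step carries over from one core to the other, and the starting values of both pairs are limits of the assay and not numbers: the limit of > 50000 nM in this assay, at which 2 of the 4 values shown sit.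

The compounds shown hold only bromo and trifluoromethyl at this place on the ring, and whether a chloro, a methoxy or a nitrile group there would behave in the same way stays open. Also open, on these data alone, is how a plain hydrogen at that place would compare on each core, a comparison that would give both groups a common reference point.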